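The compounds below may be only part of what the source reports. "The series", "measured", "known", "first", "only" and "open" are said of these compounds alone.

In a functional assay on HL-60 cells (Homo sapiens) for inhibition (on this read-out lower numbers stand for stronger inhibition of growth and higher numbers for weaker inhibition of growth), three compounds have so far been measured:

Compound 1, `C=C(C)C(=O)c1ccc(OCc2nc(C)no2)cc1C`: 3820 nM
Compound 2, `C=C(C)C(=O)c1ccc(OCc2nc(-c3ccccc3)no2)cc1C`: 6700 nM
Compound 3, `C=C(C)C(=O)c1ccc(OCc2nc(C)no2)cc1Br`: 3200 nM

Compound 2 differs from compound 1 by phenyl in place of methyl on an aromatic carbon, and this gave a 1.8-fold higher number from compound 1 to compound 2 (0.24 log units; within the scatter). Compound 3 differs from compound 1 by bromo in place of methyl on an aromatic carbon, which gave a 1.2-fold lower number from compound 1 to compound 3 (0.08 log units; within the scatter). Compound 4, `C=C(C)C(=O)c1ccc(OCc2nc(-c3ccccc3)no2)cc1Br`, has not yet been measured in this assay. It differs from compound 3 by phenyl in place of methyl on an aromatic carbon, the same change as that between compound 1 and compound 2, now made on a core that carries bromo in place of methyl. Because a 1.8-fold higher number from compound 1 to compound 2 (0.24 log units; within the scatter) stayed within the scatter, a step of similar size in this assay is expected here: a 1.8-fold higher number from compound 3 to compound 4 (0.26 log units; within the scatter). Compound 4 is therefore estimated at 5800 nM, with a likely range from 3300 nM to 10500 nM.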

Compound 4, concentration for 50% growth inhibition: 7900 nM
Estimate against measurement, compound 4: 1.4-fold (0.13 log units) below, and the stated range covers the measured number.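

In this assay, phenyl in place of methyl on the core that carries bromo gave a 2.5-fold higher number from compound 3 to compound 4 (0.39 log units; beyond the scatter), and this step agrees with the same change on the core of compound 1: the same change on two cores in this assay, a 1.8-fold higher number (0.24 log units; within the scatter) from compound 1 to compound 2 and a 2.5-fold higher number (0.39 log units; beyond the scatter) from compound 3 to compound 4, 1.4-fold (0.15 log units) apart, within the scatter of two such steps. Bromo in place of methyl, on the core that carries phenyl, gave a 1.2-fold higher number from compound 2 to compound 4 (0.07 log units; within the scatter), which also agrees with the earlier step: the same change on two cores in this assay, a 1.2-fold lower number (0.08 log units; within the scatter) from compound 1 to compound 3 and a 1.2-fold higher number (0.07 log units; within the scatter) from compound 2 to compound 4, 1.4-fold (0.15 log units) apart, within the scatter of two such steps. Both changes thus carried over between these cores with no gap beyond the scatter, but this rests on one pair of cores for each change and shows nothing about other cores or other assays.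

The compounds shown leave open how an amine, a carboxylic acid or a longer chain would behave in place of methyl on the five-membered aromatic ring. They also leave open whether chloro or methoxy in place of bromo would fit the same pattern.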